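Furan-3-yl for 3-fluorophenyl on the saturated ring carbon

The source may report more compounds than this note shows. Statements on the series, on what has been measured and on what is new or still open speak of the compounds shown alone.

Compound 1 `CC1=NC(C)=C(C(=O)O)C(c2ccccc2)/C1=C(\O)OC/C=C/c1ccccc1` is the reference of the series and gives 9 nM in a functional assay on thoracic aorta for inhibition of Voltage-gated L-type calcium channel (Rattus norvegicus); a higher number here means a weaker inhibitor, a lower number a stronger inhibitor. Compound 3 `CC1=NC(C)=C(C(=O)O)C(c2cccc(F)c2)/C1=C(\O)OC/C=C/c1ccccc1` carries fluoro in place of hydrogen on an aromatic carbon and gives 20 nM in this assay; the step of a 2.2-fold higher number from compound 1 to compound 3 (0.35 log units; beyond the scatter) is modest. Compound 2 `CC1=NC(C)=C(C(=O)O)C(c2cccc(C(=O)O)c2)/C1=C(\O)OC/C=C/c1ccccc1` gives only a limit of the assay in this assay, namely > 10000 nM. The steps of an at least 1100-fold higher number from compound 1 to compound 2 (3.04 log units; beyond the scatter) and an at least 500-fold lower number from compound 2 to compound 3 (2.69 log units; beyond the scatter) are both large, with compound 2 sitting at the limit of > 10000 nM in this assay, at which 1 of the 3 values shown sits. Of the two numbers in hand, compound 3 holds the higher one; its nearest neighbour is compound 1.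

Compound 4 `CC1=NC(C)=C(C(=O)O)C(c2ccoc2)/C1=C(\O)OC/C=C/c1ccccc1` exchanges the whole aromatic group: furan-3-yl in place of 3-fluorophenyl on a saturated ring carbon. Among the compounds with values here, no measured step swaps one aromatic ring for another; the steps from compound 1 to compound 3 and from compound 2 to compound 3 only vary a substituent on the same six-membered ring, so they bear on the present change only indirectly. They do show that small substituent changes move the number modestly while a carboxy group moves it beyond the limit. A ring swap of this kind is expected to give a step in this assay beyond the scatter towards a higher number, but well short of the shift seen for compound 2.

Compound 4 is expected at 70 nM, within 15 nM to 400 nM. The expected step is a 3.5-fold higher number from compound 3 to compound 4 (0.54 log units; beyond the scatter).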

Compound 4, half-maximal inhibitory concentration: 130 nM
The estimate for compound 4 lay 1.9-fold (0.27 log units) below the measured number; the measured number falls inside the stated range.
By their numbers in this assay, from the lowest: compound 1; then compound 3; then compound 4. At a limit, above all of these: compound 2.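

In this assay, the position on the saturated ring carbon accepts a five-membered aromatic ring with 1 hetero atom, but at a cost that no neutral substituent change in the series has matched: the swap of whole rings gives a 6.5-fold higher number from compound 3 to compound 4 (0.81 log units; beyond the scatter) and, measured against the unsubstituted phenyl, a 14-fold higher number from compound 1 to compound 4 (1.16 log units; beyond the scatter), a large step where the fluoro change gave only a 2.2-fold higher number from compound 1 to compound 3 (0.35 log units; beyond the scatter). The ring identity therefore matters here as well as the substituent on it, yet furan-3-yl stays far better placed than 3-carboxyphenyl, with an at least 76-fold lower number from compound 2 to compound 4 (1.88 log units; beyond the scatter), so the series now spans a modest loss, a large loss and complete loss of a measurable number. That last step has only a bound on one side, as the value of compound 2 is a limit of the assay: the limit of > 10000 nM in this assay, at which 1 of the 4 values shown sits.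

The compounds shown do not separate the effect of ring size from that of the ring oxygen, a question that thiophen-3-yl or pyridin-3-yl at the same carbon would address. On these data alone, whether furan-2-yl, with the oxygen placed differently, or a saturated cyclohexyl group would be tolerated also remains open.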